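Swapping the hydroxycarbamoyl end of compound 1

This account rests on a few compounds, and the source may have more. Where it says the series, first, only, none or still open, it means among the compounds named here.

In a functional assay on HEL cells (Homo sapiens) for inhibition (on this read-out lower numbers stand for stronger inhibition and higher numbers for weaker inhibition), compound 1 (`CC(C)c1cc(-c2n[nH]c(=O)n2-c2cccc(C(=O)NCCCCCCC(=O)NO)c2)c(O)cc1O`) gives 4600 nM. Compound 3 (`CC(C)c1cc(-c2n[nH]c(=O)n2-c2ccc(C(=O)NCCCC(=O)NO)cc2)c(O)cc1O`) gives 4600 nM, level with compound 1 within the scatter, and these two share the highest number of the three measured. Compound 2 (`CC(C)c1cc(-c2n[nH]c(=O)n2-c2cccc(NC(=O)CCCCC(=O)NO)c2)c(O)cc1O`) gives 1600 nM, a lower number than compound 1 and beyond the scatter. The three differ in more than one place, so no single structural change can be read from them. All three carry the hydroxycarbamoyl group.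

Compound 4 (`CNC(=O)CCCCCCCNC(=O)c1cccc(-n2c(-c3cc(C(C)C)c(O)cc3O)n[nH]c2=O)c1`) departs from compound 1 at exactly that group. The change is (methylcarbamoyl)methyl in place of hydroxycarbamoyl on a saturated chain carbon, six bonds along the chain from an amide-type nitrogen. Among the compounds with values here, no measured compound lacks hydroxycarbamoyl, so the data give no direct precedent for this step in this assay. A modest move towards a higher number, meaning weaker inhibition, is expected, possibly not far beyond the scatter, starting from the 4600 nM of compound 1. The expected size is a 1.5-fold higher number from compound 1 to compound 4 (0.18 log units; within the scatter). The estimate for compound 4 is 7000 nM, with an expected range from 2500 nM to 20000 nM.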

Compound 4, half-maximal inhibitory concentration: 4600 nM
Estimate against measurement, compound 4: 1.5-fold (0.18 log units) above; measured number inside the range.
By their numbers in this assay, from the lowest: compound 2; then compounds 1, 3 and 4 (each within the scatter of the next).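

In this assay, putting (methylcarbamoyl)methyl in place of hydroxycarbamoyl on a saturated chain carbon, six bonds along the chain from an amide-type nitrogen, gives no change at the digits printed from compound 1 to compound 4 (within the scatter) and so leaves the read-out where it was. Within the data shown here, this is the first reading on a compound without hydroxycarbamoyl, and it shows that, on the chain of compound 1, the read-out at this level does not depend on that end group. The earlier compounds all carried hydroxycarbamoyl and could not separate its contribution from that of the rest of the molecule, and no measurement on hand explains why the exchange leaves the number unmoved.

Among these compounds, it remains open whether the same exchange would be equally silent on the different chain and linkage of compound 2, the one compound with a lower number, or on compound 3. Also open, as far as these compounds go, is whether other chain ends, such as a carboxylic acid, a primary amide or an amine, or a longer chain carrying the (methylcarbamoyl)methyl end, would hold this level or move away from it.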